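This account rests on a few compounds, and the source may have more. Where it says the series, first, only, none or still open, it means among the compounds named here.

Within the data shown here, compound 2 `CNc1nc(C(F)(F)F)c(C(=O)N/N=C/c2cccc(C(F)(F)F)c2)s1` is one of three compounds measured in a functional assay on A549 cells (Homo sapiens) for inhibition, read by MTT assay, with a stated time of 72 h; a higher number here means a weaker inhibitor, a lower number a stronger inhibitor. In this assay compound 2 gives > 100 ug/mL, a limit of the assay rather than a number. Compound 1 `CNc1nc(C)c(C(=O)N/N=C/c2cccc(C(F)(F)F)c2)s1` gives > 100 ug/mL, again a limit. The step that the two limits leave unreadable from compound 1 to compound 2 therefore cannot be read, since both values sit at the limit of > 100 ug/mL in this assay, at which 2 of the 3 values shown sit. Among the measured compounds shown here, compound 3 `CN(C(=O)NC(=O)c1c(F)cccc1F)c1nc(C(F)(F)F)c(C(=O)N/N=C/c2ccc(C(F)(F)F)cc2)s1` gives 40.1 ug/mL, the only number among the three. The unmeasured compound 4 `CN(C(=O)NC(=O)c1ccccc1F)c1nc(C(F)(F)F)c(C(=O)N/N=C/c2cccc(C(F)(F)F)c2)s1` arises from compound 2 by ((2-fluorophenyl)carbonyl)carbamoyl in place of hydrogen on a nitrogen on an aromatic ring. For the measured compounds named here, no measured step covers this change; compound 3, which carries a related group, is the nearest guide. Compound 4 is expected to give about 40 ug/mL, between 15 ug/mL and 100 ug/mL, so the expected step of an at least 2.5-fold lower number from compound 2 to compound 4 (0.39 log units; beyond the scatter) is toward stronger inhibition.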

Compound 4, half-maximal inhibitory concentration: 19.5 ug/mL
Compound 4: the middle estimate sits 2.1-fold (0.31 log units) above what was measured, and the stated range covers the measured number.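

Among these compounds, putting ((2-fluorophenyl)carbonyl)carbamoyl in place of hydrogen on this nitrogen gives an at least 5.1-fold lower number from compound 2 to compound 4 (0.70 log units; beyond the scatter), the only readable step among the compounds in this assay. It shows that this nitrogen can carry the large group with stronger inhibition, which the pair of limits before it could not show. The size remains a bound, because the value of compound 2 is a limit of the assay: the limit of > 100 ug/mL in this assay, at which 2 of the 4 values shown sit.

The compounds shown leave open whether the whole group is needed, or whether a plain acetyl on this nitrogen would do the same. From the compounds shown here alone, the part played by the fluorine also stays open.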